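Replacing 4-ethylpiperazin-1-yl on the low-stability compound 2

The source may hold more compounds than are shown below. What is called first, only, known or untested is meant among the compounds shown, and "the series" means these compounds.

In an ADME assay on microsomes from liver (Homo sapiens) for metabolic stability, read by LC-MS, with a stated time of 10 min (a lower number here means that less of the compound is left, a higher number that more of the compound is left), compound 2 (`CCN1CCN(c2cccc3c2C[C@H](CN(C)[C@H]2CCCc4cccnc42)NC3)CC1`) gives 0%, the lower of the two numbers, while compound 1 (`CC(C)N1CCN(c2cccc3c2C[C@H](CN(C)[C@H]2CCCc4cccnc42)NC3)CC1`) gives 56.6%. Compound 3 (`CN(C[C@H]1Cc2c(cccc2N2C[C@H]3C[C@@H]2CN3)CN1)[C@H]1CCCc2cccnc21`) differs from compound 2 on an aromatic carbon: a group of 7 heavy atoms (5 carbon, 2 nitrogen; 2 five-membered non-aromatic rings with 1 hetero atom each) in place of a group of 8 heavy atoms (6 carbon, 2 nitrogen; one six-membered non-aromatic ring with 2 hetero atoms), on an aromatic carbon. Going by the values given here, the only measured step, a number 56.6 percentage points lower from compound 1 to compound 2 (beyond the scatter), is large and beyond the scatter, but it changes only the chain on the piperazine, so no measured step covers this ring replacement. A lower number than that of compound 2 is not possible because compound 2 gives 0% in this assay. The expected change is upward and large but uncertain: a number 32 percentage points higher from compound 2 to compound 3 (beyond the scatter). Compound 3 is estimated at 32%, with an expected range of 4% to 72%.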

Compound 3, percent of the compound remaining: 100%
Estimate against measurement, compound 3: 68 percentage points below; measured number above the stated range.
By their numbers in this assay, from the lowest: compound 2; then compound 1; then compound 3.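

On this aromatic carbon, the ring itself matters as much as the chain on the piperazine in this assay: the two-ring group gives a number 100 percentage points higher from compound 2 to compound 3 (beyond the scatter) and also a number 43.4 percentage points higher from compound 1 to compound 3 (beyond the scatter) in the same read-out. Compound 3 therefore stands highest of the three, above the best piperazine shown. Nothing at hand bears on the cause of this rise.

Still open, as far as these compounds go, is how piperazin-1-yl without any chain would stand, which would separate loss of the chain from the change of ring. Also open, from the compounds shown here alone, is whether an ethyl on the free ring nitrogen of the two-ring group keeps the gain.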